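This account rests on a few compounds, and the source may have more. Where it says the series, first, only, none or still open, it means among the compounds named here.

Measured compounds in the series:

Compound 1: `C[C@@H]1CCN(c2cc(-c3ccccc3)nc3ncnn23)C[C@@H]1N(C)c1ncnc2[nH]ccc12`, 84900 nM
Compound 2: `Cc1cc(N2CC[C@@H](C)[C@@H](N(C)c3ncnc4[nH]ccc34)C2)n2nc(SCc3ccccc3Br)nc2n1`, 27000 nM

Both numbers come from a functional assay on MGC-803 cells (Homo sapiens) for inhibition, read by MTT assay, with a stated time of 72 h; a lower number here means a stronger inhibitor, a higher number a weaker inhibitor. Compound 2 gives the lower of the two numbers, and its gap to compound 1 is beyond the scatter, so compound 2 is the stronger inhibitor of the pair. Among the compounds with values here, no step between compounds that differ in one place is available, so no measured change can be tied to a single structural edit.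

Compound 3 is `COc1ccc(CSc2nc3nc(C)cc(N4CC[C@@H](C)[C@@H](N(C)c5ncnc6[nH]ccc56)C4)n3n2)cc1`. It differs from compound 2 in one place only: 4-methoxyphenyl in place of 2-bromophenyl on a saturated chain carbon bound to a sulfur. The rest of the molecule is kept, including the shared core and the methyl-bearing saturated ring.

Nothing in the two measured compounds speaks to a change of this kind, since they differ in several places at once. With no guide from a related step, the expectation is a step without clear direction and within the scatter in this assay, and the expected step of a 1.1-fold higher number from compound 2 to compound 3 (0.05 log units; within the scatter) reflects that. Compound 3 is accordingly estimated at 30000 nM, with a range of 10000 nM to 90000 nM.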

Compound 3, half-maximal inhibitory concentration: 15200 nM
For compound 3 the middle estimate is 2.0-fold (0.30 log units) above the measured one, within the range that was stated.
By their numbers in this assay, from the lowest: compounds 3 and 2 (each within the scatter of the next); then compound 1.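

In this assay, within the data shown here, this is the first comparison that isolates one place, and it gives a 1.8-fold lower number from compound 2 to compound 3 (0.25 log units; within the scatter). On a saturated chain carbon bound to a sulfur, 2-bromophenyl and 4-methoxyphenyl therefore cannot be told apart in this read-out, even though the entering group carries a hydrogen-bond acceptor and the leaving group carries none. Nothing at hand bears on what lies behind this result.

The swap alters both the identity of the ring substituent and its numbered position in a single step, so the effects of these two changes remain unseparated; 4-bromophenyl and 2-methoxyphenyl at the same place would speak to that. Also open, from the compounds shown here alone, is how this place responds to groups of a different kind from the two substituted benzyl groups seen here, such as a longer chain ending in the same phenyl ring, a chain bearing an amine, or one bearing a carboxylic acid.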